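Swapping an aromatic tail for a short branched chain

A few compounds are considered here, and "the series" means these few. Any claim that something is new, unique, unknown or untested is made for them only; others in the source may bear on it.

Compound 1 `O=C1CC(c2ccccc2OCc2ccc(F)cc2)Oc2ccccc21` gives 45.2%.
Compound 2 `CC(C)c1ccc(COc2ccccc2C2CC(=O)c3ccccc3O2)cc1` gives 91.5%.
Compound 3 `CCCCCOc1ccccc1C1CC(=O)c2ccccc2O1` gives 41.3%.

These numbers come from a functional assay on RAW264.7 cells (Mus musculus) for inhibition, read by immunoassay, with a stated time of 12 h, tested at 30 uM; on this read-out higher numbers stand for more inhibition at the one concentration tested (going by the name of the read-out) and lower numbers for less inhibition. Compound 1 stands second highest of the three; compound 3 lies nearest, within the scatter, and compound 2 lies furthest, well beyond it. Compound 4 `CC(C)=CCOc1ccccc1C1CC(=O)c2ccccc2O1` is not yet measured. It differs from compound 1 in one place: 2-methylprop-1-en-1-yl in place of 4-fluorophenyl on a saturated chain carbon bound to an oxygen on an aromatic ring. The step that bears on this is a number 3.9 percentage points lower from compound 1 to compound 3 (within the scatter), where a plain chain likewise replaced the aromatic group at that place. The large step of a number 46.3 percentage points higher from compound 1 to compound 2 (beyond the scatter) concerns a different change and does not bear directly. Because a number 3.9 percentage points lower from compound 1 to compound 3 (within the scatter) stayed within the scatter, no step beyond the scatter is expected: a number 3.2 percentage points lower from compound 1 to compound 4 (within the scatter). Compound 4 is estimated at 42%, expected between 25% and 60%.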

Compound 4, a percentage reported as inhibition, at one concentration (the size of the read-out at that concentration, not a potency): 41.8%
Beside the measured number, compound 4's estimate is 0.2 percentage points above it, within the range that was stated.
By their numbers in this assay, from the lowest: compounds 3, 4 and 1 (each within the scatter of the next); then compound 2.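

Putting the 2-methylprop-1-en-1-yl group at this place gives a number 3.4 percentage points lower from compound 1 to compound 4 (within the scatter) and a number 0.5 percentage points higher from compound 3 to compound 4 (within the scatter) here, so a chain with a double bond reads level with both the plain butyl chain and the 4-fluorophenyl ring. Only the 4-isopropylphenyl group stands apart among these four, as a number 49.7 percentage points lower from compound 2 to compound 4 (beyond the scatter) shows for this same place. Nothing shown here explains that gap. Still open, from the compounds shown here alone, is how a 4-tert-butylphenyl ring would read at this place, and whether a chain ending in an amine or a carboxylic acid would read with the chains or with compound 2.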